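A few compounds are considered here, and "the series" means these few. Any claim that something is new, unique, unknown or untested is made for them only; others in the source may bear on it.

Measured in a functional assay on DU-145 cells (Homo sapiens) for inhibition, read by trypan blue exclusion, with a stated time of 96 h; a lower number here means a stronger inhibitor of growth, a higher number a weaker inhibitor of growth:
- compound 1 `Cc1ccc(S(=O)(=O)/C(=C/c2ccc(O)c([N+](=O)[O-])c2)C(=O)c2ccc(Cl)cc2)cc1`: 25000 nM
- compound 2 `Cc1ccc(S(=O)(=O)/C(=C/c2ccc(C)s2)C(=O)c2ccc(Cl)cc2)cc1`: 50000 nM
- compound 3 `Cc1ccc(S(=O)(=O)/C(=C/c2ccccc2F)C(=O)c2ccc(Cl)cc2)cc1`: 2500 nM

Compound 3 holds the lowest number of the three. Compound 4 `Cc1ccc(S(=O)(=O)/C(=C/c2cccs2)C(=O)c2ccc(Cl)cc2)cc1` changes one group: thiophen-2-yl in place of 2-fluorophenyl on a double-bonded chain carbon bound to a double-bonded chain carbon. All measured steps fall at this same place. The most relevant is a 20-fold lower number from compound 2 to compound 3 (1.30 log units; beyond the scatter), since compound 2 also bears a thiophene ring, as 5-methylthiophen-2-yl. A second is a 10-fold lower number from compound 1 to compound 3 (1.00 log units; beyond the scatter), while a 2.0-fold higher number from compound 1 to compound 2 (0.30 log units; within the scatter). Losing 2-fluorophenyl is therefore expected to reverse much of that gain in this assay, though no measured compound carries thiophen-2-yl itself. The expected move is a 6.0-fold higher number from compound 3 to compound 4 (0.78 log units; beyond the scatter), toward a higher number. Compound 4 is estimated at 15000 nM, with an expected range of 4000 nM to 50000 nM.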

Compound 4, concentration for 50% growth inhibition: 25000 nM
Beside the measured number, compound 4's estimate is 1.7-fold (0.22 log units) below it; low and high end bracket the measured number.
By their numbers in this assay, from the lowest: compound 3; then compounds 1, 4 and 2 (each within the scatter of the next).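

In this assay, a 10-fold higher number from compound 3 to compound 4 (1.00 log units; beyond the scatter) shows that thiophen-2-yl does not keep the low number of 2-fluorophenyl at this place. Loss of the ring methyl gives a 2.0-fold lower number from compound 2 to compound 4 (0.30 log units; within the scatter) and the change from 4-hydroxy-3-nitrophenyl gives no change at the digits printed from compound 1 to compound 4 (within the scatter), so compounds 1, 2 and 4 form one group and only compound 3 stands apart. Nothing available explains that separation. Open, on these data alone, is whether the fluorine or the six-membered ring carries the difference. Plain phenyl, 2-chlorophenyl and 2-aminophenyl at this place would separate those readings.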